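The source may report more compounds than this note shows. Statements on the series, on what has been measured and on what is new or still open speak of the compounds shown alone.

Measured so far in this series:

Compound 1, `Cc1ccc(NNC(=O)CC[C@H](N)C(=O)O)cc1`, in a functional assay, read by spectrophotometry, with a stated time of 30 min (a higher number here means a weaker inhibitor, a lower number a stronger inhibitor), gives 9.99 ug/mL.
Compound 2, `N[C@@H](CCC(=O)NNc1ccc(F)cc1)C(=O)O`, in this assay gives 13.8 ug/mL.

Compound 2 holds the highest of the two numbers, but only by a 1.4-fold higher number from compound 1 to compound 2 (0.14 log units; within the scatter), so on the data at hand compound 1 and compound 2 cannot be set in any order. Among the compounds with values here, the one measured step, methyl to fluoro on the aromatic carbon, is thus the only comparison available and it did not move the number beyond the scatter.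

Compound 3, `CS(=O)(=O)c1ccc(NNC(=O)CC[C@H](N)C(=O)O)cc1`, is not yet measured in this assay. It differs from compound 2 by methylsulfonyl in place of fluoro on an aromatic carbon. Within the data shown here, no measured pair exchanges fluoro for methylsulfonyl, or any substituent for a group of this kind, so nothing directly bears on the step. Among the measured compounds shown here, the step from compound 1 to compound 2 shows only that a small swap at this aromatic carbon left the number within the scatter; it gives no guide for a larger group entering. The expectation for compound 3 is therefore anchored on compound 2 with a wide range and no direction beyond the scatter, an estimated step of a 1.1-fold higher number from compound 2 to compound 3 (0.04 log units; within the scatter). Compound 3 is estimated at 15 ug/mL, between 5 ug/mL and 45 ug/mL.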

Compound 3, half-maximal inhibitory concentration: 9.57 ug/mL
The estimate for compound 3 lay 1.6-fold (0.20 log units) above the measured number, and the stated range covers the measured number.
By their numbers in this assay, from the lowest: compounds 3, 1 and 2 (each within the scatter of the next).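

In this assay, the aromatic carbon para to a large group now carries methylsulfonyl, with 4 heavy atoms and 2 hydrogen-bond acceptors, in place of fluoro, with 1 heavy atom and none, and the result is (a 1.4-fold lower number from compound 2 to compound 3 (0.16 log units; within the scatter)). Against methyl, the same group gives (a 1.0-fold lower number from compound 1 to compound 3 (0.02 log units; within the scatter)), so compounds 1, 2 and 3 cannot be set in any order, and a much larger group at this carbon has left the number within the scatter, which the small swap between methyl and fluoro could not show. No supporting measurement is available to account for this result.

The three compounds leave open whether an amine, a carboxylic acid or a longer alkyl chain on this aromatic carbon would also stay within the scatter of compound 1, compound 2 and compound 3. They also say nothing about methylsulfonyl or fluoro on any other carbon of the ring, or about changes to the hydrazide link or the amino acid part of the shared core.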